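Moving the Acid Outward on the Amide-Bound Ring

A few compounds are considered here, and "the series" means these few. Any claim that something is new, unique, unknown or untested is made for them only; others in the source may bear on it.

Compound 1 `O=C(O)c1ccccc1NC(=O)C(C1CCCCC1)n1c(-c2ccc(Cl)cc2)nc2cc(F)c(F)cc21` shows no measurable effect in a functional assay for agonist activity at Bile acid receptor (Homo sapiens), read by a luciferase reporter; on this read-out lower numbers stand for an effect already at smaller amounts and higher numbers for an effect only at larger amounts of compound: its result is only a limit, > 40000 nM (the limit of > 40000 nM in this assay, at which 1 of the 2 values shown sits). Compound 2 `COc1cc(C(=O)O)ccc1NC(=O)[C@H](C1CCCCC1)n1c(-c2ccc(Cl)cc2)nc2cc(F)c(F)cc21`, which carries a differently arranged acid-bearing ring, gives 10400 nM in this assay. Compound 3 `O=C(O)CCc1ccc(NC(=O)C(C2CCCCC2)n2c(-c3ccc(Cl)cc3)nc3cc(F)c(F)cc32)cc1` differs from compound 1 by 4-(2-carboxyethyl)phenyl in place of 2-carboxyphenyl on an amide-type nitrogen. Among the compounds with values here, no measured pair of compounds shows how such a change moves the read-out. From compound 1 the expected step is an at least 5.0-fold lower number from compound 1 to compound 3 (0.69 log units; beyond the scatter), toward an effect at smaller amounts. For compound 3 the estimate in this assay is 8000 nM, within a range from 2000 nM to 30000 nM.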

Compound 3, half-maximal effective concentration: 2000 nM
Compound 3: the middle estimate sits 4.0-fold (0.60 log units) above what was measured, and the stated range covers the measured number.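

Swapping 2-carboxyphenyl for 4-(2-carboxyethyl)phenyl on the amide-type nitrogen gives an at least 20-fold lower number from compound 1 to compound 3 (1.30 log units; beyond the scatter) in this assay, the first measured step at this position, and it shows that the position responds strongly to this change. The result for compound 1 is only a limit, so the step gives a minimum and not an exact size: the limit of > 40000 nM in this assay, at which 1 of the 3 values shown sits.

The step changes the place of the acid on the ring and the length of its link together, and these two effects cannot be told apart here. A 4-carboxyphenyl group, or a longer chain ending in a carboxylic acid, would help separate them.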